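Allyl carbamate as a replacement for a sulfur-bearing group

This account rests on a few compounds, and the source may have more. Where it says the series, first, only, none or still open, it means among the compounds named here.

Of the compounds shown here, three built on a shared sugar-like core have been measured in an assay on DDT1 cells (Cricetulus griseus) for binding affinity to adenosine receptor A1 (Homo sapiens), read by radioligand binding; on this read-out higher numbers stand for weaker inhibition and lower numbers for stronger inhibition. Compound 2 `CC(C)/N=C(\S)OC[C@H]1OC(n2cnc3c(NC4CCOC4)ncnc32)[C@H](O)[C@@H]1O` gives 36 nM and stands at the lowest number of the three, so it is the strongest binder here. Compound 1 `CNC(=O)OC[C@H]1OC(n2cnc3c(NC4CCOC4)nc(Cl)nc32)[C@H](O)[C@@H]1O` gives 96 nM, and compound 3 `O=C(NC1CCCC1)OC[C@H]1OC(n2cnc3c(NC4CCOC4)nc(Cl)nc32)[C@H](O)[C@@H]1O` gives 226 nM. Within the data shown here, the one step between neighbours that differ in a single place, a 2.4-fold higher number from compound 1 to compound 3 (0.37 log units; beyond the scatter), shows that enlarging the group on the amide-type nitrogen cost some affinity.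

Compound 4 `C=CCNC(=O)OC[C@H]1OC(n2cnc3c(NC4CCOC4)ncnc32)[C@H](O)[C@@H]1O` has not yet been measured. It differs from compound 2 by a group of 6 heavy atoms (4 carbon, 1 nitrogen, 1 oxygen; no ring) in place of a group of 6 heavy atoms (4 carbon, 1 nitrogen, 1 sulfur; no ring), on an oxygen on a saturated carbon. The leaving group carries a sulfur, the entering allylcarbamoyl group carries an oxygen instead, and both hold the same count of heavy atoms.

Among the measured compounds shown here, the step from compound 1 to compound 3 is the only measured guide, and it concerns a different change, so its bearing is indirect; it suggests that a small chain on the carbamate nitrogen is tolerated with only a modest loss. Compound 4 is therefore expected to give a somewhat higher number than compound 2, by about a 1.7-fold higher number from compound 2 to compound 4 (0.22 log units; within the scatter), though a result within the scatter would not surprise. The estimate for compound 4 in this assay is 60 nM, with a range from 20 nM to 180 nM.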

Compound 4, inhibition constant: 524 nM
Estimate against measurement, compound 4: 8.7-fold (0.94 log units) below, and the stated range ends below it.
By their numbers in this assay, from the lowest: compound 2; then compound 1; then compound 3; then compound 4.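

In this assay, the group on this oxygen on a saturated carbon clearly matters: putting allylcarbamoyl in place of the sulfur-bearing group gives a 15-fold higher number from compound 2 to compound 4 (1.16 log units; beyond the scatter), even though each is a group of 6 heavy atoms with no ring, 1 hydrogen-bond donor, 1 hydrogen-bond acceptor and no net charge. Matching those counts therefore does not keep the number in place, and this large step goes well past the modest one seen earlier, a 2.4-fold higher number from compound 1 to compound 3 (0.37 log units; beyond the scatter), which changed only the group on the amide-type nitrogen. Nothing measured here accounts for the size of the new step.

The step changes two things at once, the sulfur that becomes an oxygen and the chain on the nitrogen, so the compounds shown leave open which of these carries the shift. A carbamate with an isopropyl group on its nitrogen, or the sulfur-bearing group with an allyl chain on its nitrogen, would change only one of the two and so pull them apart.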